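The source may hold more compounds than are shown below. What is called first, only, known or untested is meant among the compounds shown, and "the series" means these compounds.

Working notes on the series. In a physicochemical assay for lipophilicity, using the shake flask method, in phosphate buffer, measured as octanol-water partition, at pH 7.4 (on this read-out higher numbers stand for higher lipophilicity and lower numbers for lower lipophilicity), compound 1 (`CCN1CC(CC#N)(n2cc(-c3nc(-c4cnn(C)c4)cn4nccc34)cn2)C1`) gives 2.1 and compound 2 (`Cn1ccc(-c2cn3nccc3c(-c3cnn([C@]4(CC#N)C[C@@H](C#N)C4)c3)n2)n1`) gives 1.6. Compound 2 therefore holds the lower of the two numbers, and its gap to compound 1 lies beyond the usual scatter. Compound 3 (`N#CC[C@]1(n2cc(-c3nc(-c4cc[nH]n4)cn4nccc34)cn2)C[C@H](C#N)C1`) has not yet been measured in this assay. It differs from compound 2 in one place: hydrogen in place of methyl on an aromatic nitrogen, so that 1-methyl-1H-pyrazol-3-yl becomes 1H-pyrazol-3-yl. Going by the values given here, no measured pair shows this change, so the expectation rests on the structural change alone. A modest downward move is expected, with the estimated step of a number 0.30 log units lower from compound 2 to compound 3 (within the scatter), and it may not clear the scatter. The estimate for compound 3 is 1.3, with an expected range of 0.9 to 1.7.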

Compound 3, distribution coefficient: 1.7
Estimate against measurement, compound 3: 0.40 log units below; low and high end bracket the measured number.
By their numbers in this assay, from the lowest: compounds 2 and 3 (each within the scatter of the next); then compound 1.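

Going by these compounds alone, at the aromatic nitrogen of the five-membered aromatic ring with 2 nitrogen, hydrogen in place of methyl gives a number 0.10 log units higher from compound 2 to compound 3 (within the scatter) in this assay, the only reading of this change. With one carbon as the only heavy atom leaving, and with no hydrogen-bond donors or acceptors counted on the methyl that leaves, this single pair is not separated on this read-out. No measured evidence here bears on the reason for this result.

On these data alone, whether an ethyl group, a longer chain or a chain ending in an amine on this nitrogen would stand apart from compound 2 and compound 3 in this assay remains open. A single pair also leaves open whether the same change would read alike on another part of the shared core.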